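The source may report more compounds than this note shows. Statements on the series, on what has been measured and on what is new or still open speak of the compounds shown alone.

Measured so far in a functional assay on trachea (Cavia porcellus); a higher number here means a weaker inhibitor, a lower number a stronger inhibitor:
compound 1 `CCN1CC[C@@]2(OC)OC(N)=C(C#N)[C@@H](c3ccc(Cl)cc3)[C@@H]2C1` — 14900 nM
compound 2 `CO[C@@]12CCN(Cc3ccccc3)C[C@H]1[C@H](c1ccc(Cl)cc1)C(C#N)=C(N)O2` — 18500 nM

Within the data shown here, compound 1 gives the lowest of the two numbers in this assay, yet the only measured step, a 1.2-fold higher number from compound 1 to compound 2 (0.09 log units; within the scatter), stays within the scatter. Compound 3 `CCN1CC[C@@]2(OC)OC(N)=C(C#N)[C@@H](c3ccc(N4CCCCC4)cc3)[C@@H]2C1` carries piperidin-1-yl in place of chloro on an aromatic carbon. Among the measured compounds shown here, no measured step touches that aromatic carbon; the single step known concerns the amine substituent and bears on this change only indirectly, in that it shows the shared core tolerating a change without moving the number. For compound 3 no step beyond the scatter is expected, a 1.0-fold higher number from compound 1 to compound 3 (0.00 log units; within the scatter), with an estimated value of 15000 nM and a range from 4000 nM to 60000 nM.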

Compound 3, half-maximal inhibitory concentration: 13800 nM
For compound 3 the middle estimate is 1.1-fold (0.04 log units) above the measured one, and the stated range covers the measured number.
By their numbers in this assay, from the lowest: compounds 3, 1 and 2 (each within the scatter of the next).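

In this assay, the step at this aromatic carbon (a 1.1-fold lower number from compound 1 to compound 3 (0.03 log units; within the scatter)) shows that piperidin-1-yl, with its 6 heavy atoms and one six-membered non-aromatic ring, can replace chloro without a change beyond the scatter. Among these compounds, the earlier step concerned only the amine substituent, so this is the first reading at this position. No measurement at hand accounts for this result.

Going by these compounds, whether a carboxylic acid or a primary amine on this aromatic carbon would also stay within the scatter remains open, as does whether any group here moves the number at all.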